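Swapping the sulfonamide nitrogen group of compound 1

A few compounds are considered here, and "the series" means these few. Any claim that something is new, unique, unknown or untested is made for them only; others in the source may bear on it.

Values so far in a functional assay on HeLa cells (Homo sapiens) for antiproliferative activity, read by sulforhodamine B assay, with a stated time of 72 h (on this read-out lower numbers stand for stronger inhibition and higher numbers for weaker inhibition), are these:
compound 1 (`Cc1cc(C)nc(NS(=O)(=O)c2ccc(Nc3nncc4ccccc34)cc2)n1`) gives 3.5 nM 
compound 2 (`Clc1ccc(C(/C=C/c2ccccc2)=N\Nc2nncc3ccccc23)cc1`) gives 3.3 nM 

The values of compound 1 and compound 2 lie within the scatter of each other, so neither ranks over the other. Going by the values given here, these are the only two numbers in hand. Among the compounds with values here, the two structures differ in more than one place, and no measured single-change step is available to scale the next one.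

Compound 3 (`O=S(=O)(Nc1nccs1)c1ccc(Nc2nncc3ccccc23)cc1`) has not yet been measured. It carries 1,3-thiazol-2-yl in place of 4,6-dimethylpyrimidin-2-yl on a sulfonamide nitrogen and keeps the rest of compound 1 unchanged.

In this assay a moderate step toward weaker inhibition is expected, as compound 1 at 3.5 nM already stands at a very low number and has little room to improve. Within the data shown here, the estimated change is a 4.3-fold higher number from compound 1 to compound 3 (0.63 log units; beyond the scatter) and it remains uncertain, with no measured step as a guide. For compound 3 the expected value is 15 nM, with an estimated range from 3 nM to 90 nM in this assay.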

Compound 3, half-maximal inhibitory concentration: 15 nM
Estimate against measurement, compound 3: no gap at the digits printed; the range from low to high includes it.
By their numbers in this assay, from the lowest: compounds 2 and 1 (each within the scatter of the next); then compound 3.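

In this assay, the group on a sulfonamide nitrogen now has a measured single change: 1,3-thiazol-2-yl in place of 4,6-dimethylpyrimidin-2-yl gives a 4.3-fold higher number from compound 1 to compound 3 (0.63 log units; beyond the scatter), a modest step that shows this position affects the read-out while leaving compound 3 at 15 nM. The swap replaces a six-membered aromatic ring with a five-membered one and brings in sulfur, while the hydrogen-bond donor and acceptor counts of the group stay the same, so a change in the group's ring and atoms can move the value even with those counts held equal. Nothing measured here explains the size or direction of this step.

Still open, as far as these compounds go, is which part of the change carries the step: ring size, the sulfur atom or the loss of the methyl groups, which an unsubstituted pyrimidin-2-yl on the same sulfonamide nitrogen would help to separate. Also open, from the compounds shown here alone, is how far the position extends beyond aromatic rings with two hetero atoms, for example to a plain phenyl or to a saturated ring such as morpholine.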